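Methyl on the Amide Nitrogen: a Step Expected Flat

This account rests on a few compounds, and the source may have more. Where it says the series, first, only, none or still open, it means among the compounds named here.

Compound 2 `O=C(Nc1cccnc1)c1ccc(Cl)cc1F` was tested in an ADME assay on cells for inhibition of cytochrome P450 11B1, mitochondrial (Homo sapiens), read by HTRF; on this read-out lower numbers stand for stronger inhibition and higher numbers for weaker inhibition. In this assay compound 2 gives only a limit, > 3000 nM, and no number. Compound 1 `Cc1cc(Cl)ccc1C(=O)N(C)c1cccnc1` likewise returns only a limit in this assay, > 3000 nM. For the measured compounds named here, every value so far thus sits at the limit of > 3000 nM in this assay, at which 2 of the 2 values shown sit, and compound 2 stands exactly there. Compound 3 `CN(C(=O)c1ccc(Cl)cc1F)c1cccnc1` is not yet measured; it differs from compound 2 by methyl in place of hydrogen on an amide-type nitrogen. Going by the values given here, no measured pair shows this change, and the step is expected to be a step that the limit leaves unreadable from compound 2 to compound 3, nothing beyond the scatter. Compound 3 is expected to give 6000 nM, between 2000 nM and 20000 nM, most likely again as a limit.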

Compound 3, half-maximal inhibitory concentration: > 3000 nM
Compound 3 ended at the assay's limit (the forecaster's own chance of this, stated with the estimate: 75%); the middle value is on the limit's open side.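

Compound 3, like compound 1 and compound 2, stands at a limit in this assay, so no step among them can be read: the limit of > 3000 nM in this assay, at which 3 of the 3 values shown sit.

The compounds shown leave open how strongly each inhibits, and whether methyl in place of hydrogen on an amide-type nitrogen changes that at all.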